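The compounds below may be only part of what the source reports. "The series", "measured", "known", "first", "only" and "open" are said of these compounds alone.

Measured in a functional assay on A549 cells (Homo sapiens) for antiproliferative activity, read by sulforhodamine B assay, with a stated time of 3 days; on this read-out lower numbers stand for stronger inhibition of growth and higher numbers for weaker inhibition of growth:
- compound 1 `O=C(Nc1cccc(Nc2ncc(F)c(Nc3ccc(F)cc3)n2)c1)c1cnccn1`: 10300 nM
- compound 2 `CN1CCC(C(=O)Nc2cccc(Nc3ncc(F)c(Nc4ccc(F)cc4)n3)c2)CC1`: 1330 nM
- compound 3 `CN(C)c1ccc(C(=O)Nc2cccc(Nc3ncc(F)c(Nc4ccc(F)cc4)n3)c2)cc1`: > 10000 nM, a limit and not a number

Compound 3 has no exact number in this assay, only (the limit of > 10000 nM in this assay, at which 1 of the 3 values shown sits). The next compound, compound 4 `O=C(Nc1cccc(Nc2ncc(F)c(Nc3ccc(F)cc3)n2)c1)c1ccccc1`, has not been measured. Its difference from compound 3 is hydrogen in place of dimethylamino on an aromatic carbon. In words, hydrogen stands in place of dimethylamino on an aromatic carbon, turning 4-(dimethylamino)phenyl into phenyl.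

Among the compounds with values here, no measured step makes this exact change, so the closest guide is the swaps of the group on the carbonyl carbon. Putting 1-methylpiperidin-4-yl in place of pyrazin-2-yl gave a 7.7-fold lower number from compound 1 to compound 2 (0.89 log units; beyond the scatter). Putting 4-(dimethylamino)phenyl in place of 1-methylpiperidin-4-yl gave an at least 7.5-fold higher number from compound 2 to compound 3 (0.87 log units; beyond the scatter). Replacing pyrazin-2-yl with 4-(dimethylamino)phenyl gave a step that the limit leaves unreadable from compound 1 to compound 3.

Only 1-methylpiperidin-4-yl has given a clearly lower number, and compound 4 does not carry that group. Its phenyl group is expected to leave it with the weak pair, near compound 1 at 10300 nM. No clear step is therefore expected, and the direction cannot be predicted with confidence. The expected change is an at least 1.1-fold lower number from compound 3 to compound 4 (0.04 log units; that floor lies within the scatter). Compound 4 is estimated at 9000 nM, with an expected range from 3500 nM to 25000 nM.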

Compound 4, concentration for 50% growth inhibition: 37800 nM
For compound 4 the middle estimate is 4.2-fold (0.62 log units) below the measured one; the whole stated range lies below it.
By their numbers in this assay, from the lowest: compound 2; then compound 1; then compound 4.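

In this assay, within the data shown here, compound 4 gives the first exact number for a phenyl group on the carbonyl carbon, and this makes two new comparisons possible. Phenyl in place of 1-methylpiperidin-4-yl gives a 28-fold higher number from compound 2 to compound 4 (1.45 log units; beyond the scatter), the largest readable step in this set, while phenyl in place of pyrazin-2-yl gives a 3.7-fold higher number from compound 1 to compound 4 (0.56 log units; beyond the scatter), so these two ring groups are not interchangeable at this position and the order of the exact values runs from compound 2 through compound 1 to compound 4. The steps from compound 3 to the others that cannot be read stay unreadable, as compound 3 carries only a limit and not a number: the limit of > 10000 nM in this assay, at which 1 of the 4 values shown sits.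

Whether adding dimethylamino to the phenyl ring improves or worsens growth inhibition therefore remains unsettled. Also open, going by these compounds, is whether the lower number of compound 2 would persist with a piperidin-4-yl group lacking the methyl, or with an open-chain amine on the carbonyl carbon.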